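A Bromo Substitution Tested Across Two Related Cores

This account rests on a few compounds, and the source may have more. Where it says the series, first, only, none or still open, it means among the compounds named here.

Two pairs of compounds are compared here, joined by one recurring structural change. Compound 1 `COc1ccc(C2CC(c3ccc4ccccc4c3)=NN2C2=NC(=O)/C(=C3\C(=O)Nc4ccccc43)S2)cc1` and compound 2 `COc1ccc(C2CC(c3ccc4ccccc4c3)=NN2C2=NC(=O)/C(=C3\C(=O)Nc4ccc(Br)cc43)S2)cc1` were both assessed in a functional assay on cells (Cancer cell lines, Homo sapiens) for cytotoxicity, read by sulforhodamine B assay, with a stated time of 48 h; on this read-out higher numbers stand for weaker inhibition of growth and lower numbers for stronger inhibition of growth. Compound 1 gives 13600 nM in this assay, while compound 2 gives 330 nM. The difference between them is bromo in place of hydrogen on an aromatic carbon, and the step it produced was a 41-fold lower number from compound 1 to compound 2 (1.62 log units; beyond the scatter).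

Compound 3 `COc1ccc(C2=NN(C3=NC(=O)/C(=C4\C(=O)Nc5ccccc54)S3)C(c3ccc(Cl)cc3)C2)cc1` has a different core; how the core of compound 3 differs from that of compound 1 is not broken down here. In this assay, among the measured compounds shown here, compound 3 gives 100000 nM, the highest of the three numbers measured so far, with the number for compound 1 closest to it and that for compound 2 furthest from it.

Compound 4 `COc1ccc(C2=NN(C3=NC(=O)/C(=C4\C(=O)Nc5ccc(Br)cc54)S3)C(c3ccc(Cl)cc3)C2)cc1` has not yet been measured. It differs from compound 3 by bromo in place of hydrogen on an aromatic carbon, the same change that separates compound 1 from compound 2, made at the same place. For the measured compounds named here, since the one measured instance of this change gave the step of a 41-fold lower number from compound 1 to compound 2 (1.62 log units; beyond the scatter), a step of similar direction is expected from compound 3 to compound 4, though its size is uncertain, resting on a single pair and on the number for compound 3, which is the highest recorded. The expected step is a 33-fold lower number from compound 3 to compound 4 (1.52 log units; beyond the scatter). Compound 4 is therefore estimated at 3000 nM, most likely between 500 nM and 30000 nM.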

Compound 4, concentration for total growth inhibition: 370 nM
Estimate against measurement, compound 4: 8.1-fold (0.91 log units) above; the whole stated range lies above it.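

In this assay, bromo in place of hydrogen on an aromatic carbon again lowered the number on the second core, with a 270-fold lower number from compound 3 to compound 4 (2.43 log units; beyond the scatter), so the direction of the change held in both pairs shown and neither pair goes against it. The size of the step did not carry over, however, and the step measured on one core would not have given a reliable figure for the other, as the two steps set side by side make clear: the same change on two cores in this assay, a 41-fold lower number (1.62 log units; beyond the scatter) from compound 1 to compound 2 and a 270-fold lower number (2.43 log units; beyond the scatter) from compound 3 to compound 4, 6.6-fold (0.82 log units) apart, beyond the scatter of two such steps. This shows that the benefit of the bromo group was shared by these two cores but depended in size on the core that carried it; it does not show which feature of the cores sets the size of the step, and two pairs do not establish that the same direction would hold on any further core in the series.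

The compounds shown leave open whether the gain belongs to bromo itself or would also appear with another group on the same aromatic carbon, such as a fluoro group, a nitro group, an amine or a carboxylic acid. They also leave open how bromo would behave on a different carbon of that six-membered aromatic ring.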